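Chloro Substitution in Three Related Growth Inhibitors

The compounds below may be only part of what the source reports. "The series", "measured", "known", "first", "only" and "open" are said of these compounds alone.

Measured compounds:
compound 1, `CC(=O)OC/C(=C\c1ccc(Cl)cc1)C(=O)c1ccccc1`, 4800 nM
compound 2, `CC(=O)OC/C(=C\c1ccc(Cl)cc1)C(=O)c1ccc(Cl)cc1`, 18000 nM
compound 3, `CC(=O)OC/C(=C/c1ccccc1Cl)C(=O)c1ccccc1`, 22000 nM

In a functional assay on WiDr cells (Homo sapiens) for inhibition, read by sulforhodamine B assay, with a stated time of 48 h (on this read-out lower numbers stand for stronger inhibition of growth and higher numbers for weaker inhibition of growth), compound 1 gives 4800 nM. Compound 2 differs from it by chloro in place of hydrogen on an aromatic carbon, and this gave a 3.8-fold higher number from compound 1 to compound 2 (0.57 log units; beyond the scatter). Compound 3 has the same atoms as compound 1 joined differently; the difference between the two cores is not broken down here. Compound 3 gives 22000 nM, a value that lies within the usual scatter of that of compound 2 but beyond it relative to compound 1.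

Compound 4, `CC(=O)OC/C(=C/c1ccc(Cl)cc1Cl)C(=O)c1ccccc1`, is not yet measured. It differs from compound 3 by chloro in place of hydrogen on an aromatic carbon. This is the same kind of change as that from compound 1 to compound 2, but the place differs: here the entering chloro is meta to a chloro group, which is not the case for the earlier change. Among the measured compounds shown here, the step of a 1.8-fold higher number from compound 3 to compound 4 (0.26 log units; within the scatter) is the expected one, resting on a 3.8-fold higher number from compound 1 to compound 2 (0.57 log units; beyond the scatter) as the only measured step of this kind. Compound 4 is therefore estimated at 40000 nM, between 15000 nM and 100000 nM.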

Compound 4, concentration for 50% growth inhibition: 19000 nM
Estimate against measurement, compound 4: 2.1-fold (0.32 log units) above; the measured number falls inside the stated range.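

In this assay, chloro in place of hydrogen on an aromatic carbon gave a 1.2-fold lower number from compound 3 to compound 4 (0.06 log units; within the scatter), a step within the scatter, so the clear rise in the number seen on the core of compound 1 did not reappear on the core of compound 3: the same change on two cores in this assay, a 3.8-fold higher number (0.57 log units; beyond the scatter) from compound 1 to compound 2 and a 1.2-fold lower number (0.06 log units; within the scatter) from compound 3 to compound 4, 4.3-fold (0.64 log units) apart, beyond the scatter of two such steps

This shows that, in this series, the step measured on one core was not a reliable guide to the same change on the other. It does not show that the core alone sets the outcome, since the two changes also differ in place: the chloro entering compound 4 is meta to a chloro group, which is not the case for the chloro entering compound 2, and the two steps shown cannot separate these factors.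

What the compounds shown leave open is whether a fluoro or a methoxy group entering at these places would follow either step. As far as these compounds go, it also remains open how an amine or a carboxylic acid would fare in place of the acetate ester on either core.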